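The source may report more compounds than this note shows. Statements on the series, on what has been measured and on what is new or still open speak of the compounds shown alone.

Compound 1, `COC(=O)c1sc2cc(-c3cnn(C)c3)cnc2c1N`: in a functional assay on MCF7 cells (Homo sapiens) for inhibition, read by sulforhodamine B assay, with a stated time of 48 h (on this read-out lower numbers stand for stronger inhibition of growth and higher numbers for weaker inhibition of growth), compound 1 gives > 150000 nM, which is a limit of the assay.
Compound 2, `COC(=O)c1sc2cc(-c3cccc(N)c3)cnc2c1N`: in this assay compound 2 gives > 150000 nM, which is again a limit of the assay.

Compound 2 therefore stands at the upper end of what this assay can report; it has a limit and no number. The step that the two limits leave unreadable from compound 1 to compound 2 cannot be read in size, since both of its ends sit at the limit of > 150000 nM in this assay, at which 2 of the 2 values shown sit.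

Compound 3, `COC(=O)c1sc2cc(-c3ccc(N)cc3)cnc2c1N`, differs from compound 2 by 4-aminophenyl in place of 3-aminophenyl on an aromatic carbon. No measured step bears directly on this change, and the one step shown is itself unreadable. Nothing among the two values points to growth inhibition within the reach of this assay for either measured compound. Compound 3 is therefore expected to remain at or near the limit, with an estimate of 200000 nM and a range from 50000 nM to 1000000 nM. The expected step that the limit leaves unreadable from compound 2 to compound 3 is estimated to be none beyond the scatter.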

Compound 3, concentration for 50% growth inhibition: 108000 nM
Beside the measured number, compound 3's estimate is 1.9-fold (0.27 log units) above it; low and high end bracket the measured number.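

In this assay, within the data shown here, compound 3 gives 108000 nM, the first of the three values that is a number and not a limit, so this position can carry a group that yields a readable result. Placing 4-aminophenyl where 3-aminophenyl stood gives an at least 1.3-fold lower number from compound 2 to compound 3 (0.14 log units; that floor lies within the scatter), and placing it where 1-methyl-1H-pyrazol-4-yl stood gives an at least 1.3-fold lower number from compound 1 to compound 3 (0.14 log units; that floor lies within the scatter). Each step is known only as a floor, and the step between the two limits cannot be read, because compound 1 and compound 2 both end at a limit: the limit of > 150000 nM in this assay, at which 2 of the 3 values shown sit.

As far as these compounds go, the true size of the change from 3-aminophenyl to 4-aminophenyl therefore remains open. From the compounds shown here alone, it is also open whether a hydroxyl or a carboxylic acid in place of the amine on the phenyl ring would lower the number further.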